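This account rests on a few compounds, and the source may have more. Where it says the series, first, only, none or still open, it means among the compounds named here.

Working notes on the series. Compound 1, `CC(=O)N1c2ccccc2CCC1C(=O)Nc1cc(C(F)(F)F)cc(C(F)(F)F)c1`, carries an acetyl group on the ring nitrogen of the shared core and an amide to a phenyl bearing two trifluoromethyl groups. In a functional assay on NCI-H23 cells (Homo sapiens) for cytotoxicity, read by sulforhodamine B assay, with a stated time of 72 h (a lower number here means a stronger inhibitor of growth, a higher number a weaker inhibitor of growth), compound 1 gives only a limit, > 70000 nM, and not a number. This is the limit of > 70000 nM in this assay, at which 1 of the 3 values shown sits. Compound 2, `O=C(Nc1cc(C(F)(F)F)cc(C(F)(F)F)c1)c1ccc2ccccc2n1`, keeps the same bis(trifluoromethyl)phenyl amide on a different core; in this assay compound 2 gives 1440 nM. Compound 3, `CC(=O)N1c2ccccc2CCC1C(=O)Nc1ccccc1O`, keeps the acetylated core of compound 1 but carries an amide to a phenyl bearing a hydroxyl; in this assay compound 3 gives 65700 nM. Going by the values given here, no pair of measured compounds differs in a single place, so no measured step is available. Compound 4, `CCC(=O)N1c2ccccc2CCC1C(=O)Nc1cc(C(F)(F)F)cc(C(F)(F)F)c1`, is not yet measured and differs from compound 1 by methyl in place of hydrogen on a saturated chain carbon bound to a carbonyl carbon. Compound 1 sits at the limit and compound 3, with the same acetylated core, is close to it. The step from compound 1 to compound 4 is expected to be no larger than the scatter, a step that the limit leaves unreadable from compound 1 to compound 4, with a fair chance that compound 4 again reports only a limit. Compound 4 is estimated at 80000 nM, within a range from 40000 nM to 200000 nM.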

Compound 4, concentration for 50% growth inhibition: 7820 nM
For compound 4 the middle estimate is 10-fold (1.01 log units) above the measured one; the whole stated range lies above it.
By their numbers in this assay, from the lowest: compound 2; then compound 4; then compound 3. At a limit, above all of these: compound 1.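

Going by these compounds alone, the change from acetyl to propanoyl on the nitrogen of the shared core is the first single change that can be read, and in this assay it gives an at least 8.9-fold lower number from compound 1 to compound 4 (0.95 log units; beyond the scatter). The earlier compounds shown here could not show this, as no two of them differed in one place; the acyl chain now appears as a position where a change as small as methyl in place of hydrogen on a saturated chain carbon bound to a carbonyl carbon moves the read-out beyond the scatter. The size of the step stays open on one side, since compound 1 gives only a limit and not a number: the limit of > 70000 nM in this assay, at which 1 of the 4 values shown sits.

The compounds shown leave open whether a longer chain such as butanoyl, or an amine or a carboxylic acid in place of this methyl, would lower the number further or raise it again, and whether the same change would act alike with the phenyl bearing a hydroxyl in compound 3. They also give no measured property of the methyl group, so the reason for the step remains unknown.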